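Methylcarbamoyl in Place of Cyano on the Chain

The source may report more compounds than this note shows. Statements on the series, on what has been measured and on what is new or still open speak of the compounds shown alone.

Of the compounds shown here, two have so far been tested in a functional assay on the whole organism (stomach) for inhibition, with Rattus norvegicus as the target, at a dose of 100 mg/kg by the intraduodenal route; a higher number here means more inhibition at the dose given (going by the name of the read-out), a lower number less inhibition. Compound 1, `N=C(S)CCN1N=C(c2ccc(Cl)c(Cl)c2)CCC1=O`, gives 47.2%. Compound 2, `N#CCCn1nc(-c2ccccc2)ccc1=O`, gives 10.1%, the lowest of the two numbers and beyond the scatter from compound 1. Compound 3, `CNC(=O)CCn1nc(-c2ccccc2)ccc1=O`, differs from compound 2 by methylcarbamoyl in place of cyano on a saturated chain carbon, two bonds along the chain from an aromatic nitrogen. Among the measured compounds shown here, no measured pair shows this kind of change, so only an expectation can be given: the step is expected to be a number 5.9 percentage points higher from compound 2 to compound 3 (within the scatter), a small rise hardly beyond the scatter. Compound 3 is therefore expected to give 16%, in a range from 3% to 35%.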

Compound 3, a percentage reported as inhibition, in the whole organism at one dose (the size of the read-out at that dose, not a potency): 3.5%
Compound 3: the middle estimate sits 12.5 percentage points above what was measured, and the stated range covers the measured number.
By their numbers in this assay, from the lowest: compounds 3 and 2 (each within the scatter of the next); then compound 1.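

On the saturated chain carbon, two bonds along the chain from an aromatic nitrogen, methylcarbamoyl in place of cyano gives a number 6.6 percentage points lower from compound 2 to compound 3 (within the scatter) in this assay. At this position, then, the two groups cannot be told apart, even though the entering group brings a hydrogen-bond donor that cyano lacks. Nothing available explains this result.

Going by these compounds, whether a carboxylic acid or a longer chain at this place would move the number beyond the scatter remains open. So does whether the same change would behave alike on the core of compound 1.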